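Shortening the Chain on the Aromatic Nitrogen

The compounds below may be only part of what the source reports. "The series", "measured", "known", "first", "only" and "open" are said of these compounds alone.

Three compounds have so far been measured in a functional assay (B cells) with Mus musculus as the target; on this read-out higher numbers stand for an effect only at larger amounts of compound and lower numbers for an effect already at smaller amounts:

compound 1, `C=CCn1c(=O)n([C@H]2CO[C@@H](CO)C2)c2nc(N)nc(O)c21`: 83 uM
compound 2, `CN(C)CCCn1c(=O)n(C2OC(CO)[C@@H](O)[C@H]2O)c2nc(N)nc(O)c21`: 194 uM
compound 3, `C=CCn1c(=O)n(C2C[C@H](O)C(CO)O2)c2nc(N)nc(O)c21`: 30 uM

Compound 2 stands at the highest of the three numbers. Compound 1 is nearest to it, with a lower number that lies beyond the scatter, and compound 3 is furthest, with a lower number also beyond the scatter. Neither of these two compounds differs from compound 2 in only one place, so no single change can be read from the gaps; compound 1 and compound 3 carry a different chain and a different sugar at the same time.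

Compound 4, `Cn1c(=O)n(C2OC(CO)[C@@H](O)[C@H]2O)c2nc(N)nc(O)c21`, has not yet been measured. It differs from compound 2 in one place: hydrogen in place of 2-(dimethylamino)ethyl on a saturated chain carbon bound to an aromatic nitrogen. Going by the values given here, nothing among the measured compounds isolates this chain, so the step is estimated to be modest, leaning toward a lower number: a 1.6-fold lower number from compound 2 to compound 4 (0.21 log units; within the scatter). Compound 4 is therefore expected at 120 uM, within a range from 40 uM to 400 uM.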

Compound 4, concentration for half-maximal effect: 10 uM
Estimate against measurement, compound 4: 12-fold (1.08 log units) above, outside the stated range (below it).
By their numbers in this assay, from the lowest: compound 4; then compound 3; then compound 1; then compound 2.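

In this assay, exchanging the 3-(dimethylamino)propyl chain on the aromatic nitrogen for methyl, with the rest of the molecule unchanged, gives a 19-fold lower number from compound 2 to compound 4 (1.29 log units; beyond the scatter) and so counts as a large step. Going by these compounds alone, this is the first change at this position that can be read on its own, and it shows that the read-out depends strongly on the group carried there, which the earlier compounds, differing in two places at once, could not show. Nothing available explains the size of the step.

A plain propyl chain, or a propyl chain ending in a carboxylic acid, on the same core would separate the length of the chain from its terminal amine. As far as these compounds go, whether a step of this size would also appear on the cores of compound 1 and compound 3 remains open.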